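Amide Arm Exchanged for a Dimethylamino Arm

The compounds below may be only part of what the source reports. "The series", "measured", "known", "first", "only" and "open" are said of these compounds alone.

Compound 1 `CNC(=O)C[C@@H]1C[C@@H](c2ccc(Cl)c(Cl)c2)[C@H](NC(=O)c2cc(-c3c(Cl)cnn3C)c(Cl)o2)CN1` carries a methylcarbamoyl group on a saturated chain carbon bound to a saturated ring carbon of the shared core. In an assay for inhibition of RAC-alpha serine/threonine-protein kinase (Homo sapiens), read by HTRF, with a stated time of 1 h (on this read-out higher numbers stand for weaker inhibition and lower numbers for stronger inhibition), compound 1 gives 2.64 nM. Two neighbours have been measured. Compound 2 `Cn1ncc(Cl)c1-c1cc(C(=O)N[C@@H]2CN[C@H](CC(O)CO)C[C@H]2c2ccc(Cl)c(Cl)c2)oc1Cl` gives 3.79 nM in this assay, and compound 3 `CNC(=O)C[C@@H]1C[C@@H](c2ccc(F)c(F)c2)[C@H](NC(=O)c2cc(-c3c(Cl)cnn3C)c(Cl)o2)CN1` gives 1.37 nM. On these numbers compound 1 stands closest to compound 2, with a 1.4-fold higher number from compound 1 to compound 2 (0.16 log units; within the scatter), and furthest from compound 3, with a 1.9-fold lower number from compound 1 to compound 3 (0.28 log units; within the scatter).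

Compound 4 `CN(C)CC[C@@H]1C[C@@H](c2ccc(Cl)c(Cl)c2)[C@H](NC(=O)c2cc(-c3c(Cl)cnn3C)c(Cl)o2)CN1` differs from compound 1 at that same chain carbon:

(dimethylamino)methyl in place of methylcarbamoyl on a saturated chain carbon bound to a saturated ring carbon

Within the data shown here, the step that bears most on this change is the one from compound 1 to compound 2, since it also replaces the methylcarbamoyl group at this place, and it stayed within the scatter. The step from compound 1 to compound 3 alters a different part of the molecule and was likewise within the scatter. Among the measured compounds shown here, nothing among the measured compounds points to a shift beyond the scatter, so compound 4 is expected to sit close to compound 1 in this assay, with a 1.2-fold higher number from compound 1 to compound 4 (0.08 log units; within the scatter). For compound 4 the estimated value is 3.2 nM, with a range from 1 nM to 10 nM.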

Compound 4, half-maximal inhibitory concentration: 3.4 nM
For compound 4 the middle estimate is 1.1-fold (0.03 log units) below the measured one; the range from low to high includes it.
By their numbers in this assay, from the lowest: compounds 3, 1, 4 and 2 (each within the scatter of the next, the first and the last beyond it).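

Compound 4 shows that this chain carbon tolerates a group with no carbonyl: (dimethylamino)methyl, which has 0 hydrogen-bond donors and no double bond outside aromatic rings, replaces methylcarbamoyl with a 1.3-fold higher number from compound 1 to compound 4 (0.11 log units; within the scatter) in this assay. The earlier compounds had shown only the exchange of methylcarbamoyl for 1,2-dihydroxyethyl; the new group also compares directly with that one, with a 1.1-fold lower number from compound 2 to compound 4 (0.05 log units; within the scatter), so all three groups at this place lie within the scatter of one another. Nothing shown explains why these groups read alike.

The compounds shown leave open whether this tolerance extends to a carboxylic acid, a primary amine or a longer chain on the same saturated chain carbon, since all three compounds compared here carry short, open-chain groups at this place. They also leave open whether (dimethylamino)methyl would read the same alongside the 3,4-difluorophenyl group of compound 3, because that group and the new arm do not appear together in any compound shown.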